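The source may hold more compounds than are shown below. What is called first, only, known or untested is meant among the compounds shown, and "the series" means these compounds.

Series notes. Compound 1 `O=c1[nH]c2ccccc2n1CCCCN1CCN(C(c2ccccc2)c2ccccc2)CC1` gives 180 nM in an assay on RPMI-8226 cells for antagonist activity at P2X purinoceptor 7 (Homo sapiens), read by calcium flux; on this read-out lower numbers stand for stronger inhibition and higher numbers for weaker inhibition. Among the compounds with values here, compound 2 `N#Cc1cn(CCCCN2CCN(C(c3ccccc3)c3ccccc3)CC2)c2ccccc12` gives 1500 nM in this assay, the higher of the two numbers measured so far; its nearest neighbour is compound 1, and the single step recorded, an 8.3-fold higher number from compound 1 to compound 2 (0.92 log units; beyond the scatter), lies beyond the scatter.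

Compound 3 `Fc1ccc2c(ccn2CCCCN2CCN(C(c3ccccc3)c3ccccc3)CC2)c1` is not yet measured. It differs from compound 2 by a group of 10 heavy atoms (8 carbon, 1 nitrogen, 1 fluorine; one five-membered aromatic ring with 1 hetero atom, one six-membered aromatic ring of carbon only) in place of a group of 11 heavy atoms (9 carbon, 2 nitrogen; one five-membered aromatic ring with 1 hetero atom, one six-membered aromatic ring of carbon only), on a saturated chain carbon, four bonds along the chain from an amine nitrogen in a ring. Within the data shown here, no measured step touches this change: the one step available swaps the whole group on that chain carbon for a different ring system, and it is of modest size. It therefore offers no direction for a nitrile-to-fluorine exchange within the same ring system, so nothing beyond the scatter is expected, with wide uncertainty on either side.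

Compound 3 is expected to give about 1800 nM in this assay, within a range of 500 nM to 6000 nM. The implied step a 1.2-fold higher number from compound 2 to compound 3 (0.08 log units; within the scatter) is an estimate only.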

Compound 3, half-maximal inhibitory concentration: 120 nM
The estimate for compound 3 lay 15-fold (1.18 log units) above the measured number, and the stated range ends above it.
By their numbers in this assay, from the lowest: compounds 3 and 1 (each within the scatter of the next); then compound 2.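

On the saturated chain carbon, four bonds along the chain from an amine nitrogen in a ring, the nitrile-bearing group and 5-fluoro-1H-indol-1-yl are far apart in this assay (a 13-fold lower number from compound 2 to compound 3 (1.10 log units; beyond the scatter)), so a five-membered aromatic ring with 1 hetero atom at this place is compatible with a much lower number than compound 2 alone suggested. Compound 3 also stands level with compound 1 (a 1.5-fold lower number from compound 1 to compound 3 (0.18 log units; within the scatter)), which shows that the carbonyl and the amide hydrogen of compound 1 are not required at this place for a number in that range. No measurement on hand accounts for either step.

The nitrile leaves and the fluorine enters in one exchange, so their separate shares in the step remain unresolved. On these data alone, the unsubstituted indol-1-yl group, a chlorine in place of the fluorine and a longer chain remain open.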